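The source may hold more compounds than are shown below. What is called first, only, known or untested is meant among the compounds shown, and "the series" means these compounds.

Compound 2 `COc1ccc2nc(-c3ccc(N(C)C)nc3)sc2c1` and compound 1 `CNc1ccc(-c2nc3ccc(OC)cc3s2)cn1` share one core and differ in a single place: hydrogen in place of methyl on a nitrogen on an aromatic ring. In a physicochemical assay for lipophilicity (a higher number here means a more lipophilic compound, a lower number a more polar compound), compound 2 gives 4.2, while compound 1 gives 3.2, so this change produced a number 1.00 log units lower from compound 2 to compound 1 (beyond the scatter). Compound 3 `CN(C)c1ncc(-c2nc3ccc(O)cc3s2)cn1` carries a different core; how its core differs from that of compound 2 is not broken down here. In this assay compound 3 gives 2.2, the lowest of the three numbers measured. Compound 4 `CNc1ncc(-c2nc3ccc(O)cc3s2)cn1` has not yet been measured and differs from compound 3 by hydrogen in place of methyl on a nitrogen on an aromatic ring, the same change as between compound 2 and compound 1, at a place described in identical terms. For the measured compounds named here, a step of a number 1.00 log units lower from compound 3 to compound 4 (beyond the scatter) is therefore expected, because the one earlier instance gave a number 1.00 log units lower from compound 2 to compound 1 (beyond the scatter). For compound 4 the expected value is 1.2, with a range from 0.7 to 1.7.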

Compound 4, distribution coefficient: 0.9
Beside the measured number, compound 4's estimate is 0.30 log units above it; the measured number falls inside the stated range.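

In this assay the change from dimethylamino to methylamino gives a number 1.30 log units lower from compound 3 to compound 4 (beyond the scatter) and, on the other core, a number 1.00 log units lower from compound 2 to compound 1 (beyond the scatter) so on these two cores the change carries over in direction, with both steps beyond the scatter. Two cores are a thin base, and this pair does not show that the step would hold on any further core or that its size is fixed. Nothing available bears on why the number falls with this change.

The compounds shown leave open how a longer chain, such as ethyl, on that nitrogen would compare with methyl. They also leave open whether a primary amine, with both methyl groups gone, would continue the same trend on either core.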